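This account rests on a few compounds, and the source may have more. Where it says the series, first, only, none or still open, it means among the compounds named here.

Measured compounds: compound 1, `CCCCc1nc(=O)c(S(=O)(=O)c2ccc(-c3ccnc(NC(=O)C4CC4)c3)cc2)c(O)n1-c1c(OC)cccc1OC`, gives 183 nm/s in an ADME assay for permeability, using PAMPA, at pH 5.5; on this read-out higher numbers stand for higher permeability and lower numbers for lower permeability; compound 2, `CCCCc1nc(=O)c(S(=O)(=O)c2ccc(-c3ccc(F)nc3)cc2)c(O)n1-c1c(OC)cccc1OC`, gives 516 nm/s; compound 3, `CCCCc1nc(=O)c(S(=O)(=O)c2ccccc2)c(O)n1-c1c(OC)cccc1OC`, gives 141 nm/s.

Compound 3 has the lowest of the three numbers, though against compound 1 it sits within the scatter. Compound 4, `CCCCc1nc(=O)c(S(=O)(=O)c2ccc(C)cc2)c(O)n1-c1c(OC)cccc1OC`, differs from it by methyl in place of hydrogen on an aromatic carbon, at the place where compound 2 carries a 6-fluoropyridin-3-yl group. The measured steps into that position were a 3.7-fold lower number from compound 2 to compound 3 (0.56 log units; beyond the scatter) and a 1.3-fold lower number from compound 1 to compound 3 (0.11 log units; within the scatter), both with groups far bigger than a methyl, so they set only a loose bound. A methyl is therefore expected to move this assay little, if at all, beyond the scatter, perhaps slightly upward; the expected step is a 1.4-fold higher number from compound 3 to compound 4 (0.15 log units; within the scatter). For compound 4 the estimate is 200 nm/s, within 100 nm/s to 400 nm/s.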

Compound 4, apparent permeability: 243 nm/s
Beside the measured number, compound 4's estimate is 1.2-fold (0.08 log units) below it; measured number inside the range.
By their numbers in this assay, from the lowest: compounds 3, 1 and 4 (each within the scatter of the next); then compound 2.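

In this assay, a methyl at this position stays within the scatter of both hydrogen (a 1.7-fold higher number from compound 3 to compound 4 (0.24 log units; within the scatter)) and the much larger 2-((cyclopropylcarbonyl)amino)pyridin-4-yl group (a 1.3-fold higher number from compound 1 to compound 4 (0.12 log units; within the scatter)). Only the 6-fluoropyridin-3-yl group stands clear of methyl (a 2.1-fold lower number from compound 2 to compound 4 (0.33 log units; beyond the scatter)), so a larger group here does not by itself set the number. Nothing measured here explains these steps. Still open, going by these compounds, is whether an ethyl chain, a methoxy group or a carboxylic acid at this position would stay close to methyl or approach compound 2.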